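The source may report more compounds than this note shows. Statements on the series, on what has been measured and on what is new or still open speak of the compounds shown alone.

Compound 1 `CCCNC(=S)N/N=C1\CC(c2ccc(O)cc2)Oc2cc(O)ccc21`: 31200 nM
Compound 2 `CCCN(CCC)C(=S)N/N=C1\CC(c2ccc(O)cc2)Oc2cc(O)ccc21`: 32200 nM
Compound 3 `Oc1ccc(C2C/C(=N\NC(=S)N3CCCC3)c3ccc(O)cc3O2)cc1`: 37000 nM

In a functional assay on SGC-7901 cells (Homo sapiens) for cytotoxicity, read by MTT assay, with a stated time of 72 h (on this read-out higher numbers stand for weaker inhibition and lower numbers for stronger inhibition), compound 3 gives 37000 nM. Its number is the highest of the three, yet a 1.2-fold higher number from compound 1 to compound 3 (0.07 log units; within the scatter) and a 1.1-fold higher number from compound 2 to compound 3 (0.06 log units; within the scatter) show that both gaps stay within the scatter, so the three compounds cannot be told apart on this read-out.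

Compound 4 `CC(C)(C)NC(=S)N/N=C1\CC(c2ccc(O)cc2)Oc2cc(O)ccc21` has not yet been measured. It differs from compound 3 in one place: (tert-butyl)amino in place of pyrrolidin-1-yl on a thiocarbonyl carbon. Going by the values given here, three measured steps bear on this change, each altering the group on the same thiocarbonyl carbon. a 1.0-fold higher number from compound 1 to compound 2 (0.01 log units; within the scatter), a 1.2-fold higher number from compound 1 to compound 3 (0.07 log units; within the scatter) and a 1.1-fold higher number from compound 2 to compound 3 (0.06 log units; within the scatter) were all within the scatter. Swapping one nitrogen substituent for another at this position has therefore not produced a step beyond the scatter among the compounds seen here, and the same is expected of the move from compound 3 to compound 4: the expected step is a 1.1-fold lower number from compound 3 to compound 4 (0.05 log units; within the scatter), no real change. Compound 4 is accordingly estimated at 33000 nM, with a range from 18000 nM to 60000 nM.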

Compound 4, half-maximal inhibitory concentration: 31000 nM
The estimate for compound 4 lay 1.1-fold (0.03 log units) above the measured number; the measured number falls inside the stated range.
By their numbers in this assay, from the lowest: compounds 4, 1, 2 and 3 (each within the scatter of the next).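

In this assay the ring of pyrrolidin-1-yl gives way to the ringless (tert-butyl)amino with its hydrogen-bond donor, and the result is a 1.2-fold lower number from compound 3 to compound 4 (0.08 log units; within the scatter) so neither losing the ring nor gaining that donor moves the number beyond the scatter at this thiocarbonyl carbon. The open-chain comparisons agree: dipropylamino replaced by (tert-butyl)amino gives a 1.0-fold lower number from compound 2 to compound 4 (0.02 log units; within the scatter) and tert-butyl in place of propyl on the amide-type nitrogen gives a 1.0-fold lower number from compound 1 to compound 4 (0.00 log units; within the scatter) so the four groups seen here cannot be told apart on this read-out. No evidence is available to explain this.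

From the compounds shown here alone, whether a phenyl ring, a longer chain ending in an amine or a carboxylic acid at this carbon would shift the number remains open. Also open, going by these compounds, is whether any group here can change the number, or whether the shared core alone sets it.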